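Trifluoromethyl in place of methyl: a question of stability

A few compounds are considered here, and "the series" means these few. Any claim that something is new, unique, unknown or untested is made for them only; others in the source may bear on it.

For the measured compounds named here, in an ADME assay on microsomes from liver (Mus musculus) for metabolic stability, read by LC-MS, with a stated time of 30 min, tested at 1 uM (a higher number here means that more of the compound is left, a lower number that less of the compound is left), compound 1 (`Cc1ccccc1S(=O)(=O)c1ccc(CNC(=O)c2cc3cnccc3[nH]2)cc1`) gives 15% as the only actual number so far. Going by the values given here, compound 2 (`O=C(NCc1ccc(S(=O)(=O)N2CCCCC2)cc1)c1cc2cnccc2s1`) is the one other compound tested, and its entry of "below limit of detection" (no number reported) is a remark and not a number. Compound 1 therefore has no second number to be ranked against.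

Compound 3 (`O=C(NCc1ccc(S(=O)(=O)c2ccccc2C(F)(F)F)cc1)c1cc2cnccc2[nH]1`) keeps the core of compound 1 and changes one group. The change is trifluoromethyl in place of methyl on an aromatic carbon and it turns 2-methylphenyl into 2-(trifluoromethyl)phenyl, on an aromatic carbon, ortho to a large group.

Among the compounds with values here, no measured pair of compounds shows what this exchange does in this assay so any expectation here is loose. With compound 1 at 15% on a scale of compound left, there is more room upward than downward. The expected step of a number 10 percentage points higher from compound 1 to compound 3 (within the scatter) is a modest rise, close to the edge of the usual scatter. For compound 3 the estimated value is 25% with an expected range from 8% to 50% in this reading.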

Compound 3, percent of the compound remaining: 41%
The estimate for compound 3 lay 16 percentage points below the measured number; measured number inside the range.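

In this assay, for the compounds shown here, putting trifluoromethyl in place of methyl on this aromatic carbon, ortho to a large group, gives a number 26 percentage points higher from compound 1 to compound 3 (beyond the scatter), and this is the first step in the set that can be read. Compound 1 previously had no partner differing from it in one place, whereas this pair shows that changing this single group, with the rest of the molecule held the same, is enough to shift the amount of compound left after the incubation by more than ordinary repeat variation. No measurement shown here explains the rise, so it stands as an observation and not as an explained effect.

On these data alone, a single pair gives only two points at this position, so it remains open how a chlorine atom, a methoxy group or a nitrile on the same carbon would compare with methyl and trifluoromethyl. As far as these compounds go, it is equally open whether trifluoromethyl would give a step of similar size elsewhere on this ring, or whether the exchange would carry over to other molecules.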